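The source may report more compounds than this note shows. Statements on the series, on what has been measured and on what is new or still open speak of the compounds shown alone.

Values in a functional assay on Shh Light II cells (Mus musculus) for inhibition, read by a luciferase reporter (a lower number here means a stronger inhibitor, a higher number a weaker inhibitor), so far:
- compound 1 `O=C(Nc1ccccc1Cl)N1CCC(c2nc(-c3ccc4ccccc4n3)no2)CC1` gives 510 nM
- compound 2 `COc1ccccc1N(C)C(=O)N1CCC(c2nc(-c3ccc4ccccc4n3)no2)CC1` gives 3100 nM

Of these two numbers, compound 2 at 3100 nM is the higher. Compound 3 `O=C(Nc1ccccc1C(F)(F)F)N1CCC(c2nc(-c3ccc4ccccc4n3)no2)CC1` differs from compound 2 by (2-(trifluoromethyl)phenyl)amino in place of (2-methoxyphenyl)(methyl)amino on a carbonyl carbon, with (2-(trifluoromethyl)phenyl)amino in place of (2-methoxyphenyl)(methyl)amino on a carbonyl carbon. Among the compounds with values here, one measured step bears on this change: a 6.1-fold higher number from compound 1 to compound 2 (0.78 log units; beyond the scatter), which came with (2-methoxyphenyl)(methyl)amino replacing (2-chlorophenyl)amino. The incoming group of compound 3 more closely resembles the (2-chlorophenyl)amino of compound 1 at 510 nM, so a reversal of similar size, toward a lower number, is expected in this assay. Within the data shown here, no measured compound compares trifluoromethyl with chloro directly, which leaves the range wide. The expected step is a 4.8-fold lower number from compound 2 to compound 3 (0.68 log units; beyond the scatter). Compound 3 is estimated at 650 nM, with an expected range from 220 nM to 1900 nM.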

Compound 3, half-maximal inhibitory concentration: 700 nM
For compound 3 the middle estimate is 1.1-fold (0.03 log units) below the measured one, and the stated range covers the measured number.
By their numbers in this assay, from the lowest: compounds 1 and 3 (each within the scatter of the next); then compound 2.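

In this assay the change back to an aryl amino group carrying the amide hydrogen gives a 4.4-fold lower number from compound 2 to compound 3 (0.65 log units; beyond the scatter), so the higher number of compound 2 is not tied to the loss of chloro alone. Trifluoromethyl in place of chloro gives a 1.4-fold higher number from compound 1 to compound 3 (0.14 log units; within the scatter), so the two groups cannot be told apart here. No measurement on hand accounts for these numbers. Compound 2 differs from the other two compounds in both its methoxy and its methyl on nitrogen, and the compounds shown do not separate these two changes. As far as these compounds go, it remains open whether a (2-methoxyphenyl)amino group without that methyl, an unsubstituted phenylamino group or a nitrile on the aromatic ring would match compound 1 and compound 3 or compound 2.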